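The source may report more compounds than this note shows. Statements on the series, on what has been measured and on what is new or still open speak of the compounds shown alone.

Compound 3 `Nc1ccccc1NC(=O)/C=C/c1ccc(Cn2cnc3c(NC4CCCCC4)nc(Cl)nc32)cc1` carries a cyclohexyl on a nitrogen on an aromatic ring of the shared core. In a functional assay on NCI-H460 cells (Homo sapiens) for antiproliferative activity, read by CCK-8 assay, with a stated time of 72 h, tested at 2 uM (a higher number here means a stronger effect of the compound at the concentration tested, a lower number a weaker effect), compound 3 gives 8.09%. Among the three measured compounds it sits between the other two: compound 2 `Nc1ccccc1NC(=O)/C=C/c1ccc(Cn2cnc3c(Nc4cccc(OC(F)(F)F)c4)nc(Cl)nc32)cc1` gives 2.1%, and the step of a number 6 percentage points higher from compound 2 to compound 3 (within the scatter) is one that repeat measurements could account for, whereas compound 1 `Cc1ccc(Nc2nc(Cl)nc3c2ncn3Cc2ccc(/C=C/C(=O)Nc3ccccc3N)cc2)cc1` gives 31.3%, and the step of a number 23.2 percentage points lower from compound 1 to compound 3 (beyond the scatter) is a real difference.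

Compound 4 `Nc1ccccc1NC(=O)/C=C/c1ccc(Cn2cnc3c(Nc4ccccc4)nc(Cl)nc32)cc1` differs from compound 3 in one place: phenyl in place of cyclohexyl on a nitrogen on an aromatic ring. Within the data shown here, two measured steps bear on this swap of a non-aromatic ring for an aromatic one on the same nitrogen. Going from an aromatic 4-methylphenyl to cyclohexyl gave a number 23.2 percentage points lower from compound 1 to compound 3 (beyond the scatter), a clear drop, while going from an aromatic 3-(trifluoromethoxy)phenyl to cyclohexyl gave a number 6 percentage points higher from compound 2 to compound 3 (within the scatter), nothing beyond the scatter. An aromatic ring on this nitrogen has therefore been seen both above and level with cyclohexyl, and a bare phenyl gives no further clue as to which case applies. A modest rise is expected for compound 4, a number 6.9 percentage points higher from compound 3 to compound 4 (within the scatter), with wide uncertainty. In this assay compound 4 is estimated at 15%, with a range from 4% to 34%.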

Compound 4, a percentage reported as inhibition, at one concentration (the size of the read-out at that concentration, not a potency): 2.05%
Beside the measured number, compound 4's estimate is 13 percentage points above it; the measured number lies below the stated range.
By their numbers in this assay, from the lowest: compounds 4, 2 and 3 (each within the scatter of the next); then compound 1.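

Among these compounds, the bare phenyl settles what the earlier steps left unclear: in this assay, an aromatic ring on this nitrogen does not by itself separate a compound from the cyclohexyl one, as the step of a number 6 percentage points lower from compound 3 to compound 4 (within the scatter) shows. Removing the trifluoromethoxy from the ring also leaves no measurable difference, with a number 0.1 percentage points lower from compound 2 to compound 4 (within the scatter), so compounds 2, 3 and 4 form one level group and compound 1 is the only one that stands apart. Among the compounds shown here, the single change of hydrogen in place of methyl on an aromatic carbon gives a number 29.3 percentage points lower from compound 1 to compound 4 (beyond the scatter), which places the clear difference in this small series on that one methyl rather than on the ring beneath it.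

Nothing available here gives a reason why this methyl makes such a difference. The compounds shown also leave open whether the effect is specific to methyl or would persist with an ethyl, a methoxy or a chlorine in its place, and whether a methyl on the cyclohexyl ring would bring a similar gain.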